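Phenyl in Place of Hydroxymethyl on the Alkyne Arm

This account rests on a few compounds, and the source may have more. Where it says the series, first, only, none or still open, it means among the compounds named here.

Of the compounds shown here, three built on one shared core have been tested in a functional assay on L1210 cells (Mus musculus) for inhibition; a higher number here means a weaker inhibitor, a lower number a stronger inhibitor. Compound 1 `NC(=O)c1ncn(C2O[C@H](CO)[C@@H](O)[C@H]2O)c1C#CCO` gives 0.7 ug/mL. Compound 2 `NC(=O)c1ncn(C2O[C@H](CO)[C@@H](O)[C@H]2O)c1C#Cc1ccccc1` gives 20.6 ug/mL, and compound 3 `N#Cc1ncn(C2O[C@H](CO)[C@@H](O)[C@H]2O)c1C#CCO` gives 4.1 ug/mL. Of these three numbers, compound 3 holds the second highest: the step of a 5.9-fold higher number from compound 1 to compound 3 (0.77 log units; beyond the scatter) places it behind compound 1, while the number of compound 2 lies higher still. Compound 4 `N#Cc1ncn(C2O[C@H](CO)[C@@H](O)[C@H]2O)c1C#Cc1ccccc1` has not yet been measured in this assay. It differs from compound 3 by phenyl in place of hydroxymethyl on a triple-bonded carbon. Going by the values given here, one measured step bears directly on this change, made on the core of compound 1 rather than on that of compound 3: a 29-fold higher number from compound 1 to compound 2 (1.47 log units; beyond the scatter), a large rise. If the core of compound 3 answers the same exchange in the same way, a large rise in this assay is expected, meaning a much weaker inhibitor. Compound 4 is therefore estimated at 110 ug/mL, with a likely range from 30 ug/mL to 400 ug/mL. This estimate means an expected step of a 27-fold higher number from compound 3 to compound 4 (1.43 log units; beyond the scatter), well beyond the usual scatter.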

Compound 4, half-maximal inhibitory concentration: 80.3 ug/mL
The estimate for compound 4 lay 1.4-fold (0.14 log units) above the measured number, and the stated range covers the measured number.
By their numbers in this assay, from the lowest: compound 1; then compound 3; then compound 2; then compound 4.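

In this assay, phenyl in place of hydroxymethyl on a triple-bonded carbon is costly again when the cyano group replaces the carbamoyl group, with a 20-fold higher number from compound 3 to compound 4 (1.29 log units; beyond the scatter), so the large loss of inhibition is not confined to the carbamoyl compounds, and its size holds: the same change on two cores in this assay, a 29-fold higher number (1.47 log units; beyond the scatter) from compound 1 to compound 2 and a 20-fold higher number (1.29 log units; beyond the scatter) from compound 3 to compound 4, 1.5-fold (0.18 log units) apart, within the scatter of two such steps. The reverse comparison is new as well, since cyano in place of carbamoyl also weakens inhibition when phenyl sits on the alkyne, with a 3.9-fold higher number from compound 2 to compound 4 (0.59 log units; beyond the scatter), and this step also keeps its size: the same change on two cores in this assay, a 5.9-fold higher number (0.77 log units; beyond the scatter) from compound 1 to compound 3 and a 3.9-fold higher number (0.59 log units; beyond the scatter) from compound 2 to compound 4, 1.5-fold (0.18 log units) apart, within the scatter of two such steps. Across these four compounds, each change therefore costs about the same whichever group occupies the other place.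

From the compounds shown here alone, with only hydroxymethyl and phenyl compared on the triple-bonded carbon, it remains open whether the loss follows the aromatic ring, the larger group or the missing hydroxyl. An aminomethyl group or a longer chain ending in a hydroxyl at that place would help to separate these possibilities.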